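A few compounds are considered here, and "the series" means these few. Any claim that something is new, unique, unknown or untested is made for them only; others in the source may bear on it.

Working notes on the series. The compounds share one core: compound 1 `COc1ccc(C2=NN(c3nc(-c4ccc(OC)cc4)cs3)C(c3cccs3)C2)cc1` carries methoxy on both outer rings, compound 2 `Clc1ccc(C2=NN(c3nc(-c4ccc(Br)cc4)cs3)C(c3cccs3)C2)cc1` bromo on one and chloro on the other, compound 3 `Clc1ccc(C2=NN(c3nc(-c4ccccc4)cs3)C(c3cccs3)C2)cc1` chloro alone. In a functional assay on WM 266-4 cells (Homo sapiens) for antiproliferative activity, read by MTT assay, with a stated time of 48 h (a higher number here means a weaker inhibitor, a lower number a stronger inhibitor), compound 1 gives 31600 nM, compound 2 gives 1450 nM, and compound 3 gives 2190 nM. Compound 3 thus stands second highest of the three numbers, close to compound 2 and far from compound 1. Among the compounds with values here, the only single step measured, a 1.5-fold higher number from compound 2 to compound 3 (0.18 log units; within the scatter), lies within the scatter. Compound 4 `COc1ccc(-c2csc(N3N=C(c4ccc(Cl)cc4)CC3c3cccs3)n2)cc1` differs from compound 3 by methoxy in place of hydrogen on an aromatic carbon. Within the data shown here, no measured step covers this exact change; the only pointer is indirect, since compound 1, which carries the same group together with a second one, gives 31600 nM. The expected step is a 1.8-fold higher number from compound 3 to compound 4 (0.26 log units; within the scatter), a modest rise with wide uncertainty. Compound 4 is estimated at 4000 nM, with a range of 1500 nM to 15000 nM.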

Compound 4, half-maximal inhibitory concentration: 1310 nM
Beside the measured number, compound 4's estimate is 3.1-fold (0.48 log units) above it; the whole stated range lies above it.
By their numbers in this assay, from the lowest: compounds 4, 2 and 3 (each within the scatter of the next); then compound 1.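

Methoxy on this ring leaves the number within the scatter, with a 1.7-fold lower number from compound 3 to compound 4 (0.22 log units; within the scatter) against hydrogen and a 1.1-fold lower number from compound 2 to compound 4 (0.04 log units; within the scatter) against bromo. The large change lies on the other outer ring, with a 24-fold lower number from compound 1 to compound 4 (1.38 log units; beyond the scatter) for chloro in place of methoxy, so the high number of compound 1 does not follow from the methoxy at this position. Nothing at hand gives a reason for these steps.

On these data alone, whether an amine or a carboxylic acid at this position would also stay within the scatter remains open. So does the outcome of either group on the chloro-bearing ring.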